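This account rests on a few compounds, and the source may have more. Where it says the series, first, only, none or still open, it means among the compounds named here.

The measured compounds are three. Compound 1 `CCCCc1ccc2c(c1)C(=O)C(=O)N2` gives in a functional assay on K562 cells (Homo sapiens) for antiproliferative activity, read by MTT assay, with a stated time of 48 h (a higher number here means a weaker inhibitor, a lower number a stronger inhibitor), only a limit, > 10000 nM. Compound 2 `COc1ccc(-c2ccc3c(c2)C(=O)C(=O)N3c2ccc(OC)cc2)cc1` likewise gives in this assay only a limit, > 10000 nM. Compound 3 `COc1ccc(-c2ccc3c(c2)C(=O)C(=O)N3Cc2cccc(Cl)c2)cc1` gives in this assay a number, 200 nM.

Compound 3 thus holds the only number shown; the other two values are limits, so that (the limit of > 10000 nM in this assay, at which 2 of the 3 values shown sit). Within the data shown here, the one measured step, an at least 50-fold lower number from compound 2 to compound 3 (1.69 log units; beyond the scatter), is large, but it swaps an aryl group on the ring nitrogen for a benzyl group, whereas the change to compound 4 `COc1ccc(-c2ccc3c(c2)C(=O)C(=O)N3Cc2ccc(C#N)cc2)cc1` keeps the benzyl and alters only its substituent: 4-cyanophenyl in place of 3-chlorophenyl on a saturated chain carbon bound to an amide-type nitrogen in a ring. Among the measured compounds shown here, no measured pair shows what such a change within the benzyl series does, so the step from compound 2 to compound 3 bears on it only in showing that the benzyl compound gives a number at all. Compound 4 is therefore expected to stay close to compound 3, with the step of a 1.8-fold higher number from compound 3 to compound 4 (0.24 log units; within the scatter) not expected to exceed the scatter by much in either direction. The estimate for compound 4 in this assay is 350 nM, within 100 nM to 1500 nM.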

Compound 4, half-maximal inhibitory concentration: 380 nM
Beside the measured number, compound 4's estimate is 1.1-fold (0.04 log units) below it; low and high end bracket the measured number.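

In this assay, replacing 3-chlorobenzyl with 4-cyanobenzyl on the amide-type nitrogen in a ring gives a 1.9-fold higher number from compound 3 to compound 4 (0.28 log units; within the scatter), so a number in this range does not depend on the 3-chlorobenzyl group. With an at least 26-fold lower number from compound 2 to compound 4 (1.42 log units; beyond the scatter), a second benzyl compound now stands apart from the 4-methoxyphenyl compound, so the large gap is no longer tied to a single benzyl substituent. Compound 1 and compound 2 still give only a limit: the limit of > 10000 nM in this assay, at which 2 of the 4 values shown sit.

The compounds shown leave open whether an unsubstituted benzyl, a phenethyl on the same nitrogen or an amine on the benzyl ring would keep such numbers. The change from 3-chlorobenzyl to 4-cyanobenzyl alters both the group and its place on the ring, and this one pair does not separate the two.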